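A few compounds are considered here, and "the series" means these few. Any claim that something is new, unique, unknown or untested is made for them only; others in the source may bear on it.

Measured in a functional assay on HepG2 cells (Homo sapiens) for inhibition, read by MTT assay; a higher number here means a weaker inhibitor of growth, a lower number a stronger inhibitor of growth:
- compound 1 `COc1cc2oc(-c3cccc(NC(=O)c4ccc(Br)cc4)c3)cc(=O)c2c(OC)c1OC`: 8850 nM
- compound 2 `COc1cc2oc(-c3cccc(NC(=O)c4ccc(Cl)cc4)c3)cc(=O)c2c(OC)c1OC`: 21300 nM
- compound 3 `COc1cc2oc(-c3cccc(NC(=O)c4ccc(C#N)cc4)c3)cc(=O)c2c(OC)c1OC`: 10200 nM

The three compounds differ in a single group on an aromatic carbon. Compound 3, at 10200 nM, cannot be told apart from compound 1, as the step of a 1.2-fold higher number from compound 1 to compound 3 (0.06 log units; within the scatter) shows. Compound 2 has the highest number of the three, and the step of a 2.1-fold lower number from compound 2 to compound 3 (0.32 log units; beyond the scatter) separates it from the cyano compound.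

The next compound is compound 4 `COC(=O)c1ccc(C(=O)Nc2cccc(-c3cc(=O)c4c(OC)c(OC)c(OC)cc4o3)c2)cc1`, with methoxycarbonyl in place of cyano on an aromatic carbon, para to a large group: methoxycarbonyl in place of cyano on an aromatic carbon.

Among the measured compounds shown here, no measured compound carries methoxycarbonyl, so the closest guide is the size of the swaps made so far. These are small: a 2.4-fold higher number from compound 1 to compound 2 (0.38 log units; beyond the scatter), alongside the two steps above. A step beyond the scatter in this assay is therefore not expected, and neither direction is favoured with any confidence. The expected change is a 1.2-fold higher number from compound 3 to compound 4 (0.07 log units; within the scatter). For compound 4 the estimated value is 12000 nM, with an expected range from 6000 nM to 25000 nM.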

Compound 4, concentration for 50% growth inhibition: > 100000 nM
Compound 4: a limit, no number; the forecaster's own chance of this, stated with the estimate: 5%; middle value at least 8.3-fold (0.92 log units) away from the limit.
By their numbers in this assay, from the lowest: compounds 1 and 3 (each within the scatter of the next); then compound 2. At a limit, above all of these: compound 4.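

In this assay, among the compounds shown here, compound 4 gives > 100000 nM, which is a limit of the assay and not a number, and it is the only compound at that limit: the limit of > 100000 nM in this assay, at which 1 of the 4 values shown sits. Bromo, chloro and cyano all gave readable numbers, whereas methoxycarbonyl produces an at least 9.8-fold higher number from compound 3 to compound 4 (0.99 log units; beyond the scatter), together with an at least 4.6-fold higher number from compound 2 to compound 4 (0.67 log units; beyond the scatter) and an at least 11-fold higher number from compound 1 to compound 4 (1.05 log units; beyond the scatter). The earlier swaps suggested that this place, para to a large group, changes the number only modestly, but this single change shows that it does not accept every group alike.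

As far as these compounds go, how far past the limit compound 4 lies stays open, as does which part of the methoxycarbonyl group matters. A carboxylic acid, an acetyl group or a methyl group at the same place could help separate these parts.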